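Amide aryl exchange at the acetamido end of the series

The source may hold more compounds than are shown below. What is called first, only, known or untested is meant among the compounds shown, and "the series" means these compounds.

Working notes on a small set of biaryl amides that share one core, all tested in a functional assay on A375P cells (Homo sapiens) for antiproliferative activity, read by MTT assay, with a stated time of 48 h; a higher number here means a weaker inhibitor, a lower number a stronger inhibitor. Compound 1 `Nc1cccc2c(-c3cccc(NC(=O)c4ccc(C(F)(F)F)c(Cl)c4)c3)ccnc12` gives 6100 nM. Compound 2 `Nc1cccc2c(-c3cccc(NC(=O)c4ccc(C(F)(F)F)cc4C(F)(F)F)c3)ccnc12` returns only the limit of the assay, recorded as > 20000 nM. Compound 3 `CC(=O)Nc1cccc2c(-c3cccc(NC(=O)c4ccc(C)c(C)c4)c3)ccnc12` also returns only the limit, recorded as > 20000 nM. Compound 3 therefore stands at the weak end of what is shown, a position it shares with compound 2, as summarised in the limit of > 20000 nM in this assay, at which 2 of the 3 values shown sit; compound 1 is the only member of the set that gives a number rather than a limit. Compound 4 `CC(=O)Nc1cccc2c(-c3cccc(NC(=O)c4ccc5c(c4)OCCO5)c3)ccnc12` differs from compound 3 by 2,3-dihydro-1,4-benzodioxin-6-yl in place of 3,4-dimethylphenyl on a carbonyl carbon. Among the compounds with values here, no step between two measured compounds covers this kind of exchange, so its size cannot be read from the data. The step from compound 3 to compound 4 is expected to be a step that the limit leaves unreadable from compound 3 to compound 4, that is nothing beyond the scatter. Compound 4 is accordingly estimated at 25000 nM, with a range from 8000 nM to 60000 nM, and it is expected that the assay again reports only a limit.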

Compound 4, half-maximal inhibitory concentration: 570 nM
Estimate against measurement, compound 4: 44-fold (1.64 log units) above; measured number outside the range, below it.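

In this assay, within the data shown here, the exchange of 3,4-dimethylphenyl for 2,3-dihydro-1,4-benzodioxin-6-yl on a carbonyl carbon gives an at least 35-fold lower number from compound 3 to compound 4 (1.54 log units; beyond the scatter), and this is the first readable step in the set. Among these compounds, the aryl group on this carbonyl carbon is the only difference within the pair, so with the acetamido group held constant, that group alone separates a limit from a measured number. The true size of the step stays unknown because compound 3 gives only a limit: the limit of > 20000 nM in this assay, at which 2 of the 4 values shown sit.

Phenyl and 3,4-dimethoxyphenyl on the same carbonyl carbon would be needed to tell the contribution of the two oxygen atoms from that of the closed ring. Also open, from the compounds shown here alone, is whether 2,3-dihydro-1,4-benzodioxin-6-yl has a comparable effect when the core carries a free amine in place of the acetamido group.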